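Swapping the aryl ether tail on a lactone core

A few compounds are considered here, and "the series" means these few. Any claim that something is new, unique, unknown or untested is made for them only; others in the source may bear on it.

Three compounds have been measured in a functional assay on HCT-116 cells (Homo sapiens) for cytotoxicity, read by sulforhodamine B assay, with a stated time of 72 h; on this read-out higher numbers stand for weaker inhibition and lower numbers for stronger inhibition:
Compound 1 `C=C1C(=O)O[C@@H]2CC(C)=C([C@@H](C)CCCOC(C)=O)[C@@H](OC(=O)CN(CC)CC)[C@H]12` gives 13100 nM.
Compound 2 `C=C1C(=O)O[C@@H]2CC(C)=C([C@@H](C)CCCOC(C)=O)[C@@H](OC(=O)CN3CCCCC3)[C@H]12` gives 13900 nM.
Compound 3 `C=C1C(=O)O[C@@H]2CC(C)=C([C@@H](C)CCCOC(C)=O)[C@@H](OC(=O)COc3ccc(C(=O)OCCC)cc3)[C@H]12` gives 37500 nM.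

Compound 3 has the highest number of the three in this assay, beyond the scatter from both compound 1 and compound 2. Going by the values given here, the only measured step, a 1.1-fold higher number from compound 1 to compound 2 (0.03 log units; within the scatter), changes an amine on the chain and lies within the scatter, so it does not speak to an aryl ether. Compound 4 `C=C1C(=O)O[C@@H]2CC(C)=C([C@@H](C)CCCOC(C)=O)[C@@H](OC(=O)COc3cccc4cccnc34)[C@H]12` differs from compound 3 by quinolin-8-yl in place of 4-(propoxycarbonyl)phenyl on an oxygen on a saturated carbon. Among the compounds with values here, no measured pair covers such a change, so the expectation rests only on the spread seen so far. The expected step is a 1.5-fold lower number from compound 3 to compound 4 (0.18 log units; within the scatter), a modest move towards the other two compounds. Compound 4 is estimated at 25000 nM, between 8000 nM and 70000 nM.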

Compound 4, half-maximal inhibitory concentration: 12100 nM
Compound 4: the middle estimate sits 2.1-fold (0.32 log units) above what was measured; low and high end bracket the measured number.
By their numbers in this assay, from the lowest: compounds 4, 1 and 2 (each within the scatter of the next); then compound 3.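

At this position, on an oxygen on a saturated carbon, the group on the ether does matter: in this assay, quinolin-8-yl in place of 4-(propoxycarbonyl)phenyl gives a 3.1-fold lower number from compound 3 to compound 4 (0.49 log units; beyond the scatter). An aryl ether tail therefore need not separate from the amine tails, as (quinolin-8-yl)oxy in place of diethylamino gives a 1.1-fold lower number from compound 1 to compound 4 (0.03 log units; within the scatter), and in place of piperidin-1-yl gives a 1.1-fold lower number from compound 2 to compound 4 (0.06 log units; within the scatter). Nothing measured here gives a reason for these steps. Whether the ring nitrogen of quinolin-8-yl or the propoxycarbonyl group accounts for the change stays open; plain phenyl or naphthalen-1-yl on the same oxygen would help separate the two.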